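The source may hold more compounds than are shown below. What is called first, only, known or untested is meant among the compounds shown, and "the series" means these compounds.

In a functional assay on HeLa cells (Homo sapiens) for inhibition, read by MTT assay, with a stated time of 72 h (a lower number here means a stronger inhibitor, a higher number a weaker inhibitor), three compounds sharing one core have been measured: compound 1 `COc1cc(NC(C)CCCNC(=O)Nc2ccc(F)cc2)c2ncccc2c1` gives 20000 nM, compound 3 `COc1cc(NC(C)CCCNC(=O)Nc2cc(C(F)(F)F)cc(C(F)(F)F)c2)c2ncccc2c1` gives 3100 nM, and compound 2 `COc1cc(NC(C)CCCNC(=O)NNC(=O)Nc2ccc(Br)cc2)c2ncccc2c1` gives 101000 nM, the highest of the three numbers and so the weakest inhibitor. Compound 4 `COc1cc(NC(C)CCCNC(=O)Nc2ccc(O)cc2)c2ncccc2c1` changes compound 2 as follows: 4-hydroxyphenyl in place of ((4-bromophenyl)carbamoyl)amino on an amide-type nitrogen. Here, 4-hydroxyphenyl replaces ((4-bromophenyl)carbamoyl)amino on an amide-type nitrogen. Going by the values given here, the one measured step bearing on this is a 5.1-fold higher number from compound 1 to compound 2 (0.70 log units; beyond the scatter), which brought in that same ((4-bromophenyl)carbamoyl)amino in place of 4-fluorophenyl. Undoing that kind of change suggests a step of similar size toward lower numbers in this assay, although no measured compound carries 4-hydroxyphenyl. The expected step is a 4.0-fold lower number from compound 2 to compound 4 (0.61 log units; beyond the scatter). Compound 4 is estimated at 25000 nM, with an expected range of 8000 nM to 80000 nM.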

Compound 4, half-maximal inhibitory concentration: 70000 nM
Beside the measured number, compound 4's estimate is 2.8-fold (0.45 log units) below it, and the stated range covers the measured number.
By their numbers in this assay, from the lowest: compound 3; then compound 1; then compounds 4 and 2 (each within the scatter of the next).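

In this assay, putting 4-hydroxyphenyl in place of ((4-bromophenyl)carbamoyl)amino on this amide-type nitrogen gives a 1.4-fold lower number from compound 2 to compound 4 (0.16 log units; within the scatter), so these two quite different groups cannot be told apart here. Hydroxy in place of fluoro on the aromatic carbon gives a 3.5-fold higher number from compound 1 to compound 4 (0.54 log units; beyond the scatter), showing that one small swap on that ring can produce a real step. Nothing available explains either result. Still open, as far as these compounds go, is how an amine or a carboxylic acid on that same aromatic carbon would compare with hydroxy and fluoro.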